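Swapping chloro for fluoro on a pyridinyl arm

The compounds below may be only part of what the source reports. "The series", "measured", "known", "first", "only" and "open" are said of these compounds alone.

Measured compounds:
- compound 1, `C=CC(=O)Nc1cccc(Nc2nc(Cl)nc(Nc3ccc(OCCOC)cc3)n2)c1`: "not determined" (no result reported)
- compound 2, `C=CC(=O)N1CCc2ccc(Nc3ncnc(Nc4ccc(C(=O)N5CCCCC5)cc4)n3)cc21`: 2840 nM
- compound 3, `C=CC(=O)Nc1cccc(Nc2ncnc(Nc3ccc(-c4ccc(Cl)nc4)cc3)n2)c1`: "not determined" (no result reported)

Three compounds built on a shared core were tested in a functional assay on Raji cells (Homo sapiens) for antiproliferative activity, read by CCK-8 assay, with a stated time of 24 h; on this read-out lower numbers stand for stronger inhibition and higher numbers for weaker inhibition. Only compound 2 returned a number, 2840 nM, so it is the single point of reference here. For compound 1 the result is "not determined" (no result reported), and for compound 3 it is likewise "not determined" (no result reported). Compound 3 therefore stands nowhere on the scale: no number for it exists, and nothing can be said about how it compares with compound 2.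

The next compound, compound 4, `C=CC(=O)Nc1cccc(Nc2ncnc(Nc3ccc(-c4ccc(F)nc4)cc3)n2)c1`, differs from compound 3 in one place: fluoro in place of chloro on an aromatic carbon. Within the data shown here, no measured pair shows this exact change, so its size cannot be read off anything here. Such an exchange of one halogen for another on the same aromatic carbon is generally expected to move the result little in this assay, most likely no further than the scatter, in either direction.

With no number for compound 3, the expectation for compound 4 can only lean on compound 2. Compound 4 is therefore estimated at roughly 2500 nM, with a wide range from 400 nM to 15000 nM, and the chance of a limit-only result is not small.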

Compound 4, half-maximal inhibitory concentration: 3250 nM
For compound 4 the middle estimate is 1.3-fold (0.11 log units) below the measured one; low and high end bracket the measured number.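

In this assay, among these compounds, compound 3 has only "not determined" (no result reported) as its entry, so no step to compound 4 can be read. On these data alone, what the change from 6-chloropyridin-3-yl to 6-fluoropyridin-3-yl does to the result therefore stays open. No further evidence bears on the value of compound 4.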